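A few compounds are considered here, and "the series" means these few. Any claim that something is new, unique, unknown or untested is made for them only; others in the source may bear on it.

Measured in a physicochemical assay for solubility, measured as kinetic solubility, at pH 2; a higher number here means a more soluble compound, a lower number a less soluble compound:
- compound 1 `CC(C)C(CC1C(=O)NC(=O)N1C)c1ccc(-c2ccc3cccc(F)c3c2)[nH]c1=O`: 26600 nM
- compound 2 `CCC(CC)C(/C=C1\OC(=O)NC1=O)c1ccc(-c2ccc3cccc(F)c3c2)[nH]c1=O`: 3680 nM
- compound 3 `CC(C)(/C=C1\OC(=O)NC1=O)c1ccc(-c2ccc3cccc(F)c3c2)[nH]c1=O`: 1660 nM

Compound 1 stands highest of the three, and both other compounds lie beyond the scatter from it. Next in the series is compound 4 `CC(C)C(/C=C1/C(=O)NC(=O)N1C)c1ccc(-c2ccc3cccc(F)c3c2)[nH]c1=O`, not yet measured. It differs from compound 1 in one place: a group of 9 heavy atoms (5 carbon, 2 nitrogen, 2 oxygen; one five-membered non-aromatic ring with 2 hetero atoms) in place of a group of 9 heavy atoms (5 carbon, 2 nitrogen, 2 oxygen; one five-membered non-aromatic ring with 2 hetero atoms), on a saturated chain carbon bound to an aromatic carbon and a saturated chain carbon. The change sits on a saturated chain carbon bound to an aromatic carbon and a saturated chain carbon, and the (3-methyl-2,5-dioxoimidazolidin-4-yl)methyl group is what leaves.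

For the measured compounds named here, no measured pair differs in one place only, so this change has no direct precedent. Compound 2 and compound 3 do carry a five-membered non-aromatic ring joined through a double bond outside aromatic rings, but they also differ from compound 1 elsewhere. Their values therefore give only a loose guide. With compound 2 at 3680 nM and compound 3 at 1660 nM, a downward step in this assay beyond the scatter is expected, smaller than the distance from compound 1 to either of them might suggest. The expected size is a 4.4-fold lower number from compound 1 to compound 4 (0.65 log units; beyond the scatter). For compound 4 the estimated value is 6000 nM, with an expected range of 1800 nM to 20000 nM.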

Compound 4, solubility: 8300 nM
Estimate against measurement, compound 4: 1.4-fold (0.14 log units) below, and the stated range covers the measured number.
By their numbers in this assay, from the lowest: compound 3; then compound 2; then compound 4; then compound 1.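

In this assay, for the compounds shown here, the first one-place comparison is a 3.2-fold lower number from compound 1 to compound 4 (0.51 log units; beyond the scatter) and it is read at a saturated chain carbon bound to an aromatic carbon and a saturated chain carbon. The (3-methyl-2,5-dioxoimidazolidin-4-yl)methyl group leaves, and the group that enters has the same heavy-atom composition, the same kind of ring and the same hydrogen-bond donor and acceptor counts, but brings 3 double bonds outside aromatic rings in place of 2, so a change that leaves those counts untouched still moves the number modestly beyond the scatter. No measurement in hand bears on what lies behind this step.

Compound 2 and compound 3 differ from compound 4 in more than one place, so they do not show whether the step carries over to other chains on the core or to rings of another kind. Also open, on these data alone, is how the number would respond to an amine or a carboxylic acid in place of the five-membered ring at this position, and whether a longer chain there would leave the step intact.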